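The compounds below may be only part of what the source reports. "The series", "measured", "known", "first", "only" and "open" are said of these compounds alone.

Compound 1 `Cc1cc(Cl)cc(-c2ccnc3cc(CN4C(=O)C5C(C4=O)C5(C)C)sc23)c1C[C@@H]1CNCCO1` gives 0.44 nM in an assay on isolated protein for inhibition of ubiquitin carboxyl-terminal hydrolase 7 (Homo sapiens), read by fluorescence, with stated times of 30 min and 1 h (on this read-out lower numbers stand for stronger inhibition and higher numbers for weaker inhibition), the second highest of the three numbers measured. Compound 3 `Cc1cc(Cl)cc(-c2ccnc3cc(CN4C(=O)C5CC5C4=O)sc23)c1C[C@@H]1CNCCO1` gives 0.16 nM, and a 2.8-fold lower number from compound 1 to compound 3 (0.44 log units; beyond the scatter). Compound 2 `O=C([C@H]1Cc2cc(Cl)cc(-c3ccnc4cc(C5(O)COC5)sc34)c2O1)N1CCNCC1`, which differs in several places, gives 73 nM. Compound 4 `Cc1cc(Cl)cc(-c2ccnc3cc(CN4C(=O)C5C(C4=O)C5(C)C)sc23)c1OC1CCCNC1` differs from compound 1 by (piperidin-3-yl)oxy in place of (morpholin-2-yl)methyl on an aromatic carbon, on an aromatic carbon of a six-membered aromatic ring of carbon only, ortho to a large group, ortho to a methyl group and para to a chloro group. Among the compounds with values here, no measured pair alters this group: the step from compound 1 to compound 3 changes a different position, and compound 2 differs too widely to isolate it. A shift within the scatter, or a modest one in either direction, is therefore expected. Compound 4 is expected to give about 0.8 nM, with a likely range from 0.2 nM to 3 nM. That estimate means a 1.8-fold higher number from compound 1 to compound 4 (0.26 log units; within the scatter).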

Compound 4, half-maximal inhibitory concentration: 2.4 nM
The estimate for compound 4 lay 3.0-fold (0.48 log units) below the measured number; measured number inside the range.
By their numbers in this assay, from the lowest: compound 3; then compound 1; then compound 4; then compound 2.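

Putting (piperidin-3-yl)oxy on this aromatic carbon in place of (morpholin-2-yl)methyl gives a 5.5-fold higher number from compound 1 to compound 4 (0.74 log units; beyond the scatter), so this position responds to how its atoms are joined, even though the two groups contain the same atoms. No available evidence accounts for this shift.

The step changes both the ring and the link to the aromatic carbon, so the effect of each remains unseparated. (Piperidin-3-yl)methyl or (morpholin-2-yl)oxy, each of which keeps one feature and changes the other, would be needed to tell them apart.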